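A methyl in place of bromo in a cytotoxicity test

This account rests on a few compounds, and the source may have more. Where it says the series, first, only, none or still open, it means among the compounds named here.

Within the data shown here, in an ADME assay on Vero 76 cells (Chlorocebus sabaeus) for cytotoxicity, read by MTT assay, with a stated time of 96 h (on this read-out higher numbers stand for lower toxicity in this test and lower numbers for higher toxicity in this test), compound 2 `Brc1ccc(NCc2cn(-c3ccccc3)nc2-c2ccc(Br)cc2)cc1` gives 88000 nM, the only actual number so far. Compound 3 `Cc1ccc(NCc2cn(-c3ccccc3)nc2-c2ccc(Br)cc2)cc1` replaces its (4-bromophenyl)amino with (4-methylphenyl)amino, methyl in place of bromo on an aromatic carbon, para to a large group (methyl in place of bromo on an aromatic carbon). Compound 1 `Cc1ccc(NCc2cn(-c3ccccc3)nc2-c2ccc(Cl)cc2)cc1`, which also carries (4-methylphenyl)amino, gives > 100000 nM, and this value is a limit of the assay. Among the measured compounds shown here, no measured step covers this change, so only a slight shift toward lower toxicity is expected. The expected size is a 1.1-fold higher number from compound 2 to compound 3 (0.03 log units; within the scatter). Compound 3 is estimated at 95000 nM, with an expected range of 50000 nM to 100000 nM.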

Compound 3, half-maximal cytotoxic concentration: > 100000 nM
Compound 3: no number, only a limit; the forecaster's own chance of this, stated with the estimate: 55%; at least 1.0-fold (0.02 log units) between middle value and limit.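

In this assay, methyl in place of bromo on an aromatic carbon, para to a large group, gives an at least 1.1-fold higher number from compound 2 to compound 3 (0.05 log units; that floor lies within the scatter). The step for bromo in place of chloro on an aromatic carbon, which joins the two limit values, cannot be read. The first step is only a floor, and its full size stays hidden because the value of compound 3 is a limit: the limit of > 100000 nM in this assay, at which 2 of the 3 values shown sit.

On these data alone, what an amine or a carboxylic acid at this place would give in this assay stays open. So does how far the true values of compound 1 and compound 3 lie beyond their limits.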